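Trimming the amine tail to a hydroxyethyl group

The source may report more compounds than this note shows. Statements on the series, on what has been measured and on what is new or still open speak of the compounds shown alone.

Compound 2 `Cc1ccc2nc(N3CCCc4ccc(F)cc4C3)cc(NCC3CCCCN3)c2c1` was tested in an ADME assay on HEp-2 cells (Homo sapiens) for cytotoxicity, read by CCK-8 assay, with a stated time of 5 days (on this read-out lower numbers stand for higher toxicity in this test and higher numbers for lower toxicity in this test), where compound 2 gives 23000 nM. Its only comparator is compound 1 `Cc1ccc2nc(N3CCCc4ccc(F)cc4C3)cc(NCCN3CCNCC3)c2c1`, which in this assay gives 40000 nM; the step of a 1.7-fold lower number from compound 1 to compound 2 (0.24 log units; within the scatter) leaves the two within the scatter of each other, so compound 2 stands level with compound 1 on the numbers shown. Compound 3 `Cc1ccc2nc(N3CCCc4ccc(F)cc4C3)cc(NCCO)c2c1` has not yet been measured. It differs from compound 2 by hydroxymethyl in place of piperidin-2-yl on a saturated chain carbon bound to a nitrogen on an aromatic ring. Among the compounds with values here, the one measured step, from compound 1 to compound 2, also exchanged the group on that chain carbon and moved the number hardly at all, so it bears on the present step only as a sign that changes at this position have so far done little. Within the data shown here, no measured step removes the ring entirely, and the present change is larger in what it takes away than the one already seen. On this thin evidence no step beyond the scatter is expected in this assay, with a wide range allowed. Compound 3 is therefore expected to give 40000 nM, between 15000 nM and 110000 nM. The expected step is a 1.7-fold higher number from compound 2 to compound 3 (0.24 log units; within the scatter).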

Compound 3, half-maximal cytotoxic concentration: > 100000 nM
Compound 3: only a limit was reported; the forecaster's own chance of this, stated with the estimate: 20%; middle value at least 2.5-fold (0.39 log units) from the limit.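

In this assay compound 3 carries a limit and not a number: the limit of > 100000 nM in this assay, at which 1 of the 3 values shown sits. The exchange of the ring-bearing tail for the smaller hydroxyl-ended one gives an at least 4.3-fold higher number from compound 2 to compound 3 (0.63 log units; beyond the scatter), and the matching comparison with the piperazine-bearing tail gives an at least 2.5-fold higher number from compound 1 to compound 3 (0.39 log units; beyond the scatter). On these data alone, this position therefore does respond in this read-out, where higher numbers stand for lower toxicity in this test: swapping one saturated nitrogen ring for another gave only a 1.7-fold lower number from compound 1 to compound 2 (0.24 log units; within the scatter), whereas both steps to the hydroxyl end lie beyond the scatter, and, as they rest on a limit, their full size stays unknown.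

The compounds shown do not separate the loss of the ring from the loss of its nitrogen, as the two leave together in each step, and an open-chain amine such as a dimethylamino group at the end of the same chain would bear on that question. As far as these compounds go, it also remains open whether the higher number would hold for a hydroxyl group on a longer chain, or for a methoxy group in place of the hydroxyl.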